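Chloro to Trifluoromethyl on the Outer Ring of Compound 1

The compounds below may be only part of what the source reports. "The series", "measured", "known", "first", "only" and "open" are said of these compounds alone.

Compound 1, `O=C(Nc1cccc(-n2cc(-c3ccncc3)c(-c3ccc(Cl)c(O)c3)n2)c1)Nc1ccc(Cl)c(Cl)c1`: 1380 nM
Compound 2, `COc1cc(-c2nn(-c3cccc(NC(=O)c4ccc(Cl)c(C(F)(F)F)c4)c3)cc2-c2ccncc2)ccc1Cl`: 5240 nM

Of the compounds shown here, two have been measured in a functional assay on MOLT-4 cells (Homo sapiens) for inhibition, read by sulforhodamine B assay, with a stated time of 48 h; a higher number here means a weaker inhibitor of growth, a lower number a stronger inhibitor of growth. Compound 1 gives the lower of the two numbers; the number for compound 2 stands beyond the usual scatter above it. Compound 3, `O=C(Nc1cccc(-n2cc(-c3ccncc3)c(-c3ccc(Cl)c(O)c3)n2)c1)Nc1ccc(Cl)c(C(F)(F)F)c1`, differs from compound 1 in one place: trifluoromethyl in place of chloro on an aromatic carbon. Among the measured compounds shown here, no measured pair shows this exact change, so the step from compound 1 to compound 3 is expected to be small, with no clear direction beyond the scatter, a 1.1-fold lower number from compound 1 to compound 3 (0.03 log units; within the scatter). Compound 3 is therefore estimated at 1300 nM, expected to fall between 500 nM and 3500 nM.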

Compound 3, concentration for 50% growth inhibition: 777 nM
Compound 3: the middle estimate sits 1.7-fold (0.22 log units) above what was measured; the range from low to high includes it.
By their numbers in this assay, from the lowest: compounds 3 and 1 (each within the scatter of the next); then compound 2.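

Putting trifluoromethyl in place of chloro on this ring gives a 1.8-fold lower number from compound 1 to compound 3 (0.25 log units; within the scatter) in this assay. Among the compounds shown here, this is the first direct reading at this position: a group of 4 heavy atoms stands where a group of 1 stood, and the number stays within the usual scatter. No other measurement here helps to explain this result.

The compounds shown leave open how a nitrile or an amine would fare at this same position. They also leave open whether the same swap would give a similar step on a different core.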